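A few compounds are considered here, and "the series" means these few. Any claim that something is new, unique, unknown or untested is made for them only; others in the source may bear on it.

Of the compounds shown here, three have been tested in an assay on isolated protein for displacement of a labelled ligand from metabotropic glutamate receptor 5 (Homo sapiens), with a stated time of 60 min, tested at 1 uM; on this read-out higher numbers stand for more inhibition at the one concentration tested (going by the name of the read-out) and lower numbers for less inhibition. Compound 1 `COCC1CCN(c2c(S(=O)(=O)c3cc(F)cc(F)c3)cnc3cc(F)ccc23)CC1` gives 83% in this assay. Compound 2 `COCC1CCN(c2c(S(=O)(=O)c3cccc(C#N)c3)cnc3cc(F)ccc23)CC1` gives 91% in this assay. The change from compound 1 to compound 2 is 3-cyanophenyl in place of 3,5-difluorophenyl on a sulfonyl sulfur, and it produced a number 8 percentage points higher from compound 1 to compound 2 (within the scatter). Compound 3 `CC1CCN(c2c(S(=O)(=O)c3cc(F)cc(F)c3)cnc3ccc(Cl)cc23)CC1` gives 93% in this assay, a number that lies within the usual scatter of both compound 1 and compound 2, so no ordering among the three can be read from these values. The difference between the core of compound 3 and the core of compound 1 is not broken down here.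

Compound 4 `CC1CCN(c2c(S(=O)(=O)c3cccc(C#N)c3)cnc3ccc(Cl)cc23)CC1` has not yet been measured. It differs from compound 3 by 3-cyanophenyl in place of 3,5-difluorophenyl on a sulfonyl sulfur, the same change as that from compound 1 to compound 2, made at a place described in the same words. Because the earlier step of a number 8 percentage points higher from compound 1 to compound 2 (within the scatter) stayed within the scatter, the step from compound 3 to compound 4 is expected to be small as well, about a number 1 percentage points higher from compound 3 to compound 4 (within the scatter). Compound 4 is therefore estimated to give 94% in this assay, most likely between 86% and 99%.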

Compound 4, a percentage reported as inhibition, at one concentration (the size of the read-out at that concentration, not a potency): 90%
The estimate for compound 4 lay 4 percentage points above the measured number; the measured number falls inside the stated range.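

In this assay, putting 3-cyanophenyl in place of 3,5-difluorophenyl on a sulfonyl sulfur gave a number 3 percentage points lower from compound 3 to compound 4 (within the scatter). Set beside the same change on the other core, this step does not stand apart from it: the same change on two cores in this assay, a number 8 percentage points higher (within the scatter) from compound 1 to compound 2 and a number 3 percentage points lower (within the scatter) from compound 3 to compound 4, 11 percentage points apart, within the scatter of two such steps. So on these two cores the swap leaves the read-out within its usual scatter, but this does not prove that the change has no effect or that the cores respond to it in the same way, as both steps are small, only two cores are compared, and a reading at one concentration gives the size of the inhibition at that concentration and not a potency.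

The compounds shown carry only these two substituted phenyl groups on the sulfonyl sulfur, so it remains open how a group such as an amine, a carboxylic acid or a longer alkyl chain would behave at that place. They also leave open which of the differences between the core of compound 1 and the core of compound 3 matter in this assay.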